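Replacing the naphthylmethyl thioether with a propargyl group

A few compounds are considered here, and "the series" means these few. Any claim that something is new, unique, unknown or untested is made for them only; others in the source may bear on it.

Of the compounds shown here, three sharing one core have been measured in a functional assay on PC-9 cells (Homo sapiens) for inhibition, read by MTT assay, with a stated time of 72 h; on this read-out lower numbers stand for stronger inhibition and higher numbers for weaker inhibition. Compound 1 `Cc1cc(Nc2cc(-c3ccccc3)[nH]n2)n2nc(SCc3ccc([N+](=O)[O-])cc3)nc2n1` gives 7980 nM, compound 2 `Cc1cc(Nc2cc(-c3ccccc3)[nH]n2)n2nc(SCc3c(Cl)cccc3Cl)nc2n1` gives 5180 nM, and compound 3 `Cc1cc(Nc2cc(-c3ccccc3)[nH]n2)n2nc(SCc3cccc4ccccc34)nc2n1` gives 3950 nM, the lowest of the three numbers, though only its gap to compound 1 is beyond the scatter: a 2.0-fold lower number from compound 1 to compound 3 (0.31 log units; beyond the scatter), while a 1.5-fold lower number from compound 1 to compound 2 (0.19 log units; within the scatter) and a 1.3-fold lower number from compound 2 to compound 3 (0.12 log units; within the scatter). Compound 4 `C#CCSc1nc2nc(C)cc(Nc3cc(-c4ccccc4)[nH]n3)n2n1` differs from compound 3 by ethynyl in place of naphthalen-1-yl on a saturated chain carbon bound to a sulfur. Every measured step exchanged one aromatic group for another, and none tested so small a group; the steps were small and those bearing on an aromatic group removed say little here. Compound 4 is therefore expected to give 8000 nM, in the range 2500 nM to 25000 nM, a step of a 2.0-fold higher number from compound 3 to compound 4 (0.31 log units; beyond the scatter) that is estimated to lean toward a higher number.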

Compound 4, half-maximal inhibitory concentration: > 50000 nM
Compound 4: no number, only a limit; the forecaster's own chance of this, stated with the estimate: 15%; middle value at least 6.2-fold (0.79 log units) from the limit.
By their numbers in this assay, from the lowest: compounds 3, 2 and 1 (each within the scatter of the next, the first and the last beyond it). At a limit, above all of these: compound 4.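

In this assay compound 4 stands at a limit and not at a number: the limit of > 50000 nM in this assay, at which 1 of the 4 values shown sits. Ethynyl in place of an aromatic group on a saturated chain carbon bound to a sulfur shifts the number far more than any exchange among the aromatic groups: an at least 12-fold higher number from compound 3 to compound 4 (1.10 log units; beyond the scatter), an at least 9.6-fold higher number from compound 2 to compound 4 (0.98 log units; beyond the scatter) and an at least 6.2-fold higher number from compound 1 to compound 4 (0.79 log units; beyond the scatter). Among these four compounds, a measurable number is seen only with an aromatic group at this place.

From the compounds shown here alone, how a plain phenyl, a cyclohexyl or a propyl group would read there stays open. Whether the lost rings or the entering triple bond accounts for the change also stays open.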